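A few compounds are considered here, and "the series" means these few. Any claim that something is new, unique, unknown or untested is made for them only; others in the source may bear on it.

In an assay on membranes from HeLa cells for displacement of a labelled ligand from adenosine receptor A3 (Homo sapiens), read by scintillation counting, with a stated time of 180 min, tested at 1 uM (a higher number here means more inhibition at the concentration tested (going by the name of the read-out), a lower number less inhibition), compound 2 `CC1=C(C(=O)OCc2ccccc2)C(c2ccco2)NC(=O)N1` gives 3%. Compound 1 `CCCOC(=O)C1=C(C)NC(=O)NC1c1ccco1` gives 3% in this assay, and compound 3 `CC1=C(C(=O)OC(C)(C)C)C(c2ccoc2)NC(=O)N1` gives 2%. The one step among these, no change at the digits printed from compound 1 to compound 2 (within the scatter), touches only the ester chain, so compound 2 stands level with compound 1 and close to compound 3, with no separation beyond the scatter among the three. Compound 4 `CC1=C(C(=O)OCc2ccccc2)C(c2cccs2)NC(=O)N1` differs from compound 2 by thiophen-2-yl in place of furan-2-yl on a saturated ring carbon. No measured step alters this ring, so nothing shows how such an exchange moves this assay; the flat numbers across all three compounds give no reason to expect a change beyond the scatter, and the step is estimated as no change at the digits printed from compound 2 to compound 4 (within the scatter). Compound 4 is therefore expected to give 3% in this assay, within -5% to 12%.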

Compound 4, a percentage reported as inhibition, at one concentration (the size of the read-out at that concentration, not a potency): 8%
Compound 4: the middle estimate sits 5 percentage points below what was measured, and the stated range covers the measured number.
By their numbers in this assay, from the lowest: compounds 3, 1, 2 and 4 (each within the scatter of the next).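

In this assay the exchange of thiophen-2-yl for furan-2-yl on the saturated ring carbon gives a number 5 percentage points higher from compound 2 to compound 4 (within the scatter) and so does not separate the two compounds. The earlier step touched only the ester chain, whereas this one shows that, with that chain held constant, sulfur in place of oxygen in this five-membered aromatic ring leaves the numbers level. Nothing available bears on why this is so.

On these data alone, it remains open whether a cyclohexyl group or a phenyl ring carrying an amine or a carboxylic acid at this position would lift the inhibition clear of the scatter. The same question stands for a longer chain on the ester.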